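Replacing the whole side chain with carbamoyl on the shared core

The source may hold more compounds than are shown below. What is called first, only, known or untested is meant among the compounds shown, and "the series" means these compounds.

Measured compounds in a functional assay on HCT-116 cells (Homo sapiens) for inhibition; a higher number here means a weaker inhibitor, a lower number a stronger inhibitor:
compound 1 `CCNC(=O)c1noc(-c2cc(C(C)C)c(O)cc2O)c1-c1cc(COCC(=O)OC)no1`, 262 nM;
compound 2 `CCNC(=O)c1noc(-c2cc(C(C)C)c(O)cc2O)c1-c1cc(CNC(C)=O)no1`, 167 nM;
compound 3 `CCNC(=O)c1noc(-c2cc(C(C)C)c(O)cc2O)c1-c1cc(CN2CCN(C)CC2)no1`, 340 nM.

Compound 1 gives the second highest of the three numbers in this assay, with compound 3 within the scatter of it and compound 2 also within the scatter. Compound 4 `CCNC(=O)c1noc(-c2cc(C(C)C)c(O)cc2O)c1-c1cc(C(N)=O)no1` has not been measured. It differs from compound 1 as follows: carbamoyl in place of ((methoxycarbonyl)methoxy)methyl on an aromatic carbon. The two measured steps from compound 1 change only the end of that same side chain, giving a 1.6-fold lower number from compound 1 to compound 2 (0.20 log units; within the scatter) and a 1.3-fold higher number from compound 1 to compound 3 (0.11 log units; within the scatter), and the step from compound 2 to compound 3 is a 2.0-fold higher number from compound 2 to compound 3 (0.31 log units; beyond the scatter). None of these tells what happens when the chain is removed and a carbamoyl group stands in its place, so the expectation rests only on the narrow spread of the three numbers. The number for compound 4 in this assay is expected to stay close to compound 1, an estimated step of a 1.0-fold lower number from compound 1 to compound 4 (0.00 log units; within the scatter), with no change beyond the scatter. Compound 4 is therefore estimated at 260 nM, in a range from 100 nM to 700 nM.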

Compound 4, half-maximal inhibitory concentration: 79 nM
For compound 4 the middle estimate is 3.3-fold (0.52 log units) above the measured one, and the stated range ends above it.
By their numbers in this assay, from the lowest: compound 4; then compounds 2, 1 and 3 (each within the scatter of the next, the first and the last beyond it).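

In this assay, placing carbamoyl directly on the aromatic carbon does what no change at the end of the side chain did, giving a 3.3-fold lower number from compound 1 to compound 4 (0.52 log units; beyond the scatter) and a 2.1-fold lower number from compound 2 to compound 4 (0.33 log units; beyond the scatter) and a 4.3-fold lower number from compound 3 to compound 4 (0.63 log units; beyond the scatter) as well. Compound 4 is thus the strongest inhibitor of the four, and this position responds more to replacing the whole side chain than the earlier exchanges at its end had shown, the largest of those being a 2.0-fold higher number from compound 2 to compound 3 (0.31 log units; beyond the scatter) in size. No measurement given here explains this difference.

Going by these compounds, it remains open whether the lower number comes from the carbamoyl group itself or from the loss of the chain. A hydroxymethyl group, a carboxylic acid or an N-methyl amide at the same place would help to separate these two readings.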